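This account rests on a few compounds, and the source may have more. Where it says the series, first, only, none or still open, it means among the compounds named here.

Measured compounds

- compound 1, `COc1ccc2c(=O)c(Cc3coc4cccc(OCC5CCCCC5)c4c3=O)coc2c1` — in a functional assay on NUGC-3 cells (Homo sapiens) for antiproliferative activity, read by XTT assay (a higher number here means a weaker inhibitor, a lower number a stronger inhibitor), compound 1 gives 1440 nM
- compound 2, `Cc1ccc2c(=O)c(Cc3coc4cccc(OCC5CCCCC5)c4c3=O)coc2c1` — in this assay compound 2 gives 2150 nM

Compound 2 holds the highest of the two numbers so far, but its only neighbour is compound 1, and the step of a 1.5-fold higher number from compound 1 to compound 2 (0.17 log units; within the scatter) does not rise above the scatter; on the numbers shown the two compounds are not separable.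

Compound 3, `O=c1c(Cc2coc3cccc(OCC4CCCCC4)c3c2=O)coc2cc(O)ccc12`, has not been measured. It differs from compound 2 by hydroxy in place of methyl on an aromatic carbon. Going by the values given here, the one step that bears on this position is the exchange from compound 1 to compound 2, which stayed within the scatter, so a change at this carbon has so far moved nothing discernibly. Among the compounds with values here, no step yet introduces a hydroxy here, so the direction is open.

On that basis compound 3 is expected near the two neighbours, with a 1.3-fold lower number from compound 2 to compound 3 (0.13 log units; within the scatter) amounting to no shift beyond the scatter. Estimate for compound 3 in this assay: 1600 nM, with a range of 600 nM to 4500 nM.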

Compound 3, half-maximal inhibitory concentration: 3220 nM
Compound 3: the middle estimate sits 2.0-fold (0.30 log units) below what was measured; low and high end bracket the measured number.
By their numbers in this assay, from the lowest: compounds 1, 2 and 3 (each within the scatter of the next, the first and the last beyond it).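

In this assay, going by these compounds alone, this aromatic carbon is no longer silent: a 2.2-fold higher number from compound 1 to compound 3 (0.35 log units; beyond the scatter) is the first step here to clear the scatter, though only modestly, and it shows that removing the methyl from the oxygen of the methoxy group changes the reading. The exchange of methyl for hydroxy, a 1.5-fold higher number from compound 2 to compound 3 (0.18 log units; within the scatter), stays within the scatter, so compound 2 cannot be separated from either oxygen-bearing neighbour, and only the methoxy and hydroxy pair can be told apart. No measurement available here accounts for the difference between those two compounds.

As far as these compounds go, whether the number can move further from this carbon remains open, for instance with an amine or a carboxylic acid in place of the hydroxy. A longer chain on the oxygen, such as ethoxy, would test whether the methoxy reading extends to larger ethers.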